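The source may hold more compounds than are shown below. What is called first, only, known or untested is meant among the compounds shown, and "the series" means these compounds.

Compound 1 `NC(=O)c1c(NC(=O)c2ccccc2Cl)sc2c1CCN(C(=S)Nc1ccc(C(F)(F)F)cc1)C2` gives 7590 nM in a functional assay on HL-60 cells (Homo sapiens) for antiproliferative activity, with a stated time of 24 h; on this read-out lower numbers stand for stronger inhibition and higher numbers for weaker inhibition.
Compound 2 `COc1ccc(NC(=S)N2CCc3c(sc(NC(=O)c4ccccc4Cl)c3C(N)=O)C2)cc1` gives 15700 nM in this assay.
Compound 3 `NC(=O)c1c(NC(=O)c2ccccc2I)sc2c1CCN(C(=S)Nc1ccccc1C(F)(F)F)C2` gives 19700 nM in this assay.

Compound 2 differs from compound 1 by methoxy in place of trifluoromethyl on an aromatic carbon, and this change gave a 2.1-fold higher number from compound 1 to compound 2 (0.32 log units; beyond the scatter). The difference between the core of compound 1 and the core of compound 3 is not broken down here; compound 3 lies beyond the scatter from compound 1 but within the scatter of compound 2. Compound 4 `COc1ccccc1NC(=S)N1CCc2c(sc(NC(=O)c3ccccc3I)c2C(N)=O)C1` has not yet been measured in this assay. It differs from compound 3 by methoxy in place of trifluoromethyl on an aromatic carbon. This is the same kind of change as that from compound 1 to compound 2, but the place differs: in compound 4 the methoxy stands ortho to a large group, whereas in compound 2 it stands para to a large group. Resting on the single earlier step of a 2.1-fold higher number from compound 1 to compound 2 (0.32 log units; beyond the scatter), a step of a 1.6-fold higher number from compound 3 to compound 4 (0.21 log units; within the scatter) is expected. Compound 4 is therefore estimated at 32000 nM, most likely between 14000 nM and 75000 nM.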

Compound 4, half-maximal inhibitory concentration: > 50000 nM
Compound 4: no number, only a limit; the forecaster's own chance of this, stated with the estimate: 20%; at least 1.5-fold (0.19 log units) between middle value and limit.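

In this assay compound 4 gives > 50000 nM, which is a limit of the assay and not a number. Methoxy in place of trifluoromethyl thus gives an at least 2.5-fold higher number from compound 3 to compound 4 (0.40 log units; beyond the scatter), so the change raises the number on both cores shown, and the two steps can only be set side by side as follows: the same change on two cores in this assay, a 2.1-fold higher number (0.32 log units; beyond the scatter) from compound 1 to compound 2 and an at least 2.5-fold higher number (0.40 log units; beyond the scatter) from compound 3 to compound 4; the limit leaves it open whether they differ This does not show how large the step on the second core is, and the methoxy also stands in a different place on the two cores, so any effect of core and of place cannot be told apart: the limit of > 50000 nM in this assay, at which 1 of the 4 values shown sits.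

The compounds shown leave open whether an amine or a nitrile in place of trifluoromethyl would follow the same course on these cores.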